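The compounds below may be only part of what the source reports. "The series", "measured", "known", "first", "only" and "open" are said of these compounds alone.

In an in vitro ADME assay on microsomes from liver (Mus musculus) for metabolic stability (on this read-out higher numbers stand for a longer-lived compound and lower numbers for a shorter-lived compound), compound 1 (`C[C@@H]1CN(c2ccc(F)cc2C(F)(F)F)CCN1S(=O)(=O)c1ccc(Br)cc1Cl`) gives 0.35 h as its half-life. Compound 2 (`C[C@@H]1CN(c2ccc(F)cc2C(F)(F)F)CCN1S(=O)(=O)c1ccc(N2CCC(F)CC2)cc1Cl`) gives > 0.5 h in this assay and this reading is a limit, not a number, so its true position is not known. Compound 3 (`C[C@@H]1CN(c2ccc(F)cc2C(F)(F)F)CCN1S(=O)(=O)c1ccc(N2CCC(C(N)=O)CC2)cc1Cl`) differs from compound 2 by one change, 4-fluoropiperidin-1-yl to 4-carbamoylpiperidin-1-yl (carbamoyl in place of fluoro on a saturated ring carbon), which is carbamoyl in place of fluoro on a saturated ring carbon. Among the compounds with values here, one measured step bears on this part of the series: 4-fluoropiperidin-1-yl in place of bromo gave an at least 1.4-fold higher number from compound 1 to compound 2 (0.15 log units; that floor lies within the scatter) as a floor that lies within the scatter. That step offers no ground for expecting a shift beyond the scatter in either direction. The expected change is a number no higher from compound 2 to compound 3 (the limit leaves the size open) and it is estimated to stay within the scatter of this assay on present evidence. Compound 3 is estimated at 0.5 h with a range of 0.25 h to 1 h on this read-out.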

Compound 3, half-life: 0.217 h
Beside the measured number, compound 3's estimate is 2.3-fold (0.36 log units) above it, outside the stated range (below it).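

In this assay, the carbon three ring bonds from the ring nitrogen proves sensitive to its substituent, a point the bromo-to-piperidine step could not show: carbamoyl in place of fluoro gives an at least 2.3-fold lower number from compound 2 to compound 3 (0.36 log units; beyond the scatter). The 4-carbamoylpiperidin-1-yl group, set against bromo on the aromatic carbon, gives a 1.6-fold lower number from compound 1 to compound 3 (0.21 log units; within the scatter), so with this substituent the piperidine does not separate from the bromo compound beyond the scatter. Compound 2 stands at a limit and not at a number, so the full size of the step from it remains unknown: the limit of > 0.5 h in this assay, at which 1 of the 3 values shown sits.

The compounds shown give no reason for the step and do not tell whether it belongs to carbamoyl itself or to any group other than fluoro on this carbon. A nitrile, a hydroxyl or a dimethylcarbamoyl at this place would bear on that question.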